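Swapping a Methyl for Chloro on the Benzyl Ring

A few compounds are considered here, and "the series" means these few. Any claim that something is new, unique, unknown or untested is made for them only; others in the source may bear on it.

Compound 2 `Cc1ccc(CN2CCN(CC(=O)Nc3ccc(-c4nc(-c5ccccc5)c(-c5ccccc5)n4C)cc3)CC2)cc1` stands lowest of the two numbers in a functional assay on MCF7 cells (Homo sapiens) for cytotoxicity, read by MTT assay, with a stated time of 24 h, tested at 16 ug/mL (a higher number here means a stronger effect of the compound at the concentration tested, a lower number a weaker effect), where compound 2 gives 26%. Its nearest neighbour, compound 1 `CCN1CCN(CC(=O)Nc2ccc(-c3nc(-c4ccccc4)c(-c4ccccc4)n3C)cc2)CC1`, gives 32.8% in this assay. For the measured compounds named here, the only measured step, a number 6.8 percentage points lower from compound 1 to compound 2 (within the scatter), altered a different part of the molecule and stayed within the scatter. Compound 3 `Cn1c(-c2ccc(NC(=O)CN3CCN(Cc4ccc(Cl)cc4)CC3)cc2)nc(-c2ccccc2)c1-c1ccccc1` differs from compound 2 by chloro in place of methyl on an aromatic carbon. Going by the values given here, no measured step touches this position, so the expected step is small: a change of a number 2 percentage points higher from compound 2 to compound 3 (within the scatter) is estimated, within the scatter. Compound 3 is therefore expected to give 28%, with a range from 15% to 42%.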

Compound 3, a percentage reported as activity, at one concentration (the size of the read-out at that concentration, not a potency): 46.2%
Beside the measured number, compound 3's estimate is 18.2 percentage points below it, outside the stated range (above it).
By their numbers in this assay, from the lowest: compounds 2 and 1 (each within the scatter of the next); then compound 3.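

In this assay, this aromatic carbon, para to a large group, proves sensitive to its substituent: chloro in place of methyl, one heavy atom for another, gives a number 20.2 percentage points higher from compound 2 to compound 3 (beyond the scatter). The 4-chlorobenzyl group also separates from the methyl-ended chain of compound 1, with a number 13.4 percentage points higher from compound 1 to compound 3 (beyond the scatter), whereas compound 1 and compound 2 lay within the scatter of each other. Nothing available here accounts for the difference between chloro and methyl. As far as these compounds go, whether fluoro, bromo or methoxy at this carbon would read like chloro or like methyl remains open.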